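A Larger Group on a Chain Already at the Limit

The source may hold more compounds than are shown below. What is called first, only, known or untested is meant among the compounds shown, and "the series" means these compounds.

- Compound 1 `C=CC(=O)Nc1cccc(Oc2nc(Nc3ccc(OC)cc3)nc3c2CSCC3)c1` gives 20900 nM
- Compound 2 `C/C=C/C(=O)Nc1cccc(Oc2nc(Nc3ccc(OC)cc3)nc3c2CSCC3)c1` gives > 50000 nM (a limit)

These two compounds were tested in a functional assay on HeLa cells (Homo sapiens) for antiproliferative activity, read by MTT assay, with a stated time of 72 h; on this read-out higher numbers stand for weaker inhibition and lower numbers for stronger inhibition. Compound 2 reads > 50000 nM, which is a limit of the assay and not a number. Its place on the scale is the limit of > 50000 nM in this assay, at which 1 of the 2 values shown sits.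

Compound 3 `COc1ccc(Nc2nc3c(c(Oc4cccc(NC(=O)/C=C/C(C)C)c4)n2)CSCC3)cc1` differs from it in one place: isopropyl in place of methyl on a double-bonded chain carbon bound to a double-bonded chain carbon. Seen one bond further out, prop-1-en-1-yl becomes 3-methylbut-1-en-1-yl.

Within the data shown here, the only measured step on this chain is an at least 2.3-fold higher number from compound 1 to compound 2 (0.37 log units; beyond the scatter), with prop-1-en-1-yl in place of vinyl. A single step is thin ground, but it points towards weaker inhibition. In this assay, a small further rise or no change beyond the scatter is therefore expected, not a recovery of activity. The expected size of the change is a step that the limit leaves unreadable from compound 2 to compound 3. The estimate for compound 3 is 70000 nM, with an expected range of 30000 nM to 200000 nM, and the assay may well report only a limit again.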

Compound 3, half-maximal inhibitory concentration: 22900 nM
The estimate for compound 3 lay 3.1-fold (0.49 log units) above the measured number; the whole stated range lies above it.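

In this assay, activity does not simply fade as the end of this chain grows: isopropyl in place of methyl on a double-bonded chain carbon bound to a double-bonded chain carbon gives an at least 2.1-fold lower number from compound 2 to compound 3 (0.33 log units; beyond the scatter). The reading of compound 2 is a limit of the assay and not a number, so this step shows only a minimum size: the limit of > 50000 nM in this assay, at which 1 of the 3 values shown sits. Exchanging the vinyl group for the larger group at the chain end gives a 1.1-fold higher number from compound 1 to compound 3 (0.04 log units; within the scatter), so the larger group at the chain end is tolerated as well as the plain vinyl group, and of the three compounds only compound 2 stands apart.

Why prop-1-en-1-yl alone should read so differently from both its smaller and its larger neighbour cannot be told from these compounds. On these data alone, whether other groups in the same place would follow compound 3 or compound 2 also stays open, for instance a tert-butyl group, a cyclopropyl ring or a dimethylamino group at the end of the chain.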